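The compounds below may be only part of what the source reports. "The series", "measured", "known", "first", "only" and "open" are said of these compounds alone.

Measured so far in a functional assay on MCF7 cells (Homo sapiens) for antiproliferative activity, read by MTT assay, with a stated time of 48 h; a higher number here means a weaker inhibitor, a lower number a stronger inhibitor:
Compound 1 `Cc1ccc(C)c(-n2nncc2CN2C(=O)C3(C(C#N)=C(N)Oc4c(N)cc5nc6ccccc6nc5c43)c3ccccc32)c1` gives > 50000 nM, a limit of the assay.
Compound 2 `Cc1cc(C)cc(-n2nncc2CN2C(=O)C3(C(C#N)=C(N)Oc4c(N)cc5nc6ccccc6nc5c43)c3ccccc32)c1` gives > 50000 nM, also a limit.
Compound 3 `COc1ccc(OC)c(-n2nncc2CN2C(=O)C3(C(C#N)=C(N)Oc4c(N)cc5nc6ccccc6nc5c43)c3ccccc32)c1` gives 28100 nM.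

Going by the values given here, compound 3 carries the only number in this assay; the other two values are limits (the limit of > 50000 nM in this assay, at which 2 of the 3 values shown sit). Compound 4 `N#CC1=C(N)Oc2c(N)cc3nc4ccccc4nc3c2C12C(=O)N(Cc1cnnn1-c1ccc(F)c(Cl)c1)c1ccccc12` is not yet measured and differs from compound 3 by 3-chloro-4-fluorophenyl in place of 2,5-dimethoxyphenyl on an aromatic nitrogen. The measured steps at this position are an at least 1.7-fold lower number from compound 1 to compound 3 (0.25 log units; that floor lies within the scatter) and an at least 1.7-fold lower number from compound 2 to compound 3 (0.25 log units; that floor lies within the scatter); both move toward the 2,5-dimethoxyphenyl and rest on a limit, and a step that the two limits leave unreadable from compound 1 to compound 2 is unreadable. Among the compounds with values here, no measured step leaves the 2,5-dimethoxyphenyl for the 3-chloro-4-fluorophenyl, so the direction of the step in this assay cannot be read; a number close to compound 3 or a return toward the limit are both open. Compound 4 is therefore expected at 40000 nM, in the range 12000 nM to 120000 nM, an expected step of a 1.4-fold higher number from compound 3 to compound 4 (0.15 log units; within the scatter).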

Compound 4, half-maximal inhibitory concentration: 17800 nM
Compound 4: the middle estimate sits 2.2-fold (0.35 log units) above what was measured; the range from low to high includes it.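

In this assay, the 3-chloro-4-fluorophenyl on the aromatic nitrogen is a second group that gives a number rather than a limit: the limit of > 50000 nM in this assay, at which 2 of the 4 values shown sit.

Replacing the 2,5-dimethoxyphenyl with this group gives a 1.6-fold lower number from compound 3 to compound 4 (0.20 log units; within the scatter), so the two oxygen acceptors are not required for a readable value in this pair. Against the dimethylphenyl compounds, the new group gives an at least 2.8-fold lower number from compound 2 to compound 4 (0.44 log units; beyond the scatter) and an at least 2.8-fold lower number from compound 1 to compound 4 (0.44 log units; beyond the scatter), the first steps at this position beyond the scatter, both resting on a limit.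

From the compounds shown here alone, whether chlorine or fluorine alone would hold the value of compound 4 stays open. So does the effect of an amine or a carboxylic acid on this phenyl ring.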